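The source may report more compounds than this note shows. Statements on the series, on what has been measured and on what is new or still open speak of the compounds shown alone.

In a functional assay on HUVEC cells (Homo sapiens) for inhibition (a lower number here means a stronger inhibitor, a higher number a weaker inhibitor), compound 1 `CN(c1ccc(NS(=O)(=O)Cc2ccccc2)cc1)c1ccnc(Nc2cccc(CS(C)(=O)=O)c2)n1` gives 350 nM, compound 2 `CN(c1ccc(NC(=N)Nc2ccccc2)cc1)c1ccnc(Nc2cccc(CS(C)(=O)=O)c2)n1` gives 596 nM and compound 3 `CN(c1ccc(NC(=O)Nc2ccc(OC(F)(F)F)cc2)cc1)c1ccnc(Nc2cccc(CS(C)(=O)=O)c2)n1` gives 7 nM, the lowest number of the three and well beyond the scatter of the other two. Compound 4 `CN(c1ccc(NC(=O)NC2CCCC2)cc1)c1ccnc(Nc2cccc(CS(C)(=O)=O)c2)n1` has cyclopentyl in place of 4-(trifluoromethoxy)phenyl on an amide-type nitrogen. Among the compounds with values here, the only measured step, a 1.7-fold higher number from compound 1 to compound 2 (0.23 log units; within the scatter), lies within the scatter and concerns a different exchange, so it offers little guidance, and no measured pair isolates this change. Compound 3, at 7 nM, stands so low that a rise is the likelier direction. The expected change is an estimated 8.6-fold higher number from compound 3 to compound 4 (0.93 log units; beyond the scatter). For compound 4 the estimated value is 60 nM, with an expected range of 12 nM to 300 nM.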

Compound 4, half-maximal inhibitory concentration: 1 nM
The estimate for compound 4 lay 60-fold (1.78 log units) above the measured number; measured number below the stated range.
By their numbers in this assay, from the lowest: compound 4; then compound 3; then compounds 1 and 2 (each within the scatter of the next).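

At this amide-type nitrogen in this assay, an aromatic ring is not required for a low number: cyclopentyl, with fewer heavy atoms than 4-(trifluoromethoxy)phenyl, gives a 7.0-fold lower number from compound 3 to compound 4 (0.85 log units; beyond the scatter). The larger gaps, a 600-fold lower number from compound 2 to compound 4 (2.78 log units; beyond the scatter) and a 350-fold lower number from compound 1 to compound 4 (2.54 log units; beyond the scatter), show how far this compound stands from the two earlier ones, although those steps replace more than the ring. Nothing available bears on why the number falls.

As far as these compounds go, whether a cyclohexyl, cyclobutyl or unsubstituted phenyl on the same nitrogen would give a similar number remains open.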